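Adding trifluoromethyl to compound 3

The source may report more compounds than this note shows. Statements on the series, on what has been measured and on what is new or still open speak of the compounds shown alone.

Measured in a functional assay on MCF7 cells (Homo sapiens) for cytotoxicity, read by WST assay, with a stated time of 72 h; on this read-out lower numbers stand for stronger inhibition and higher numbers for weaker inhibition:
- compound 1 `O=C1Nc2c(ccc(F)c2F)C1(c1ccc(O)cc1)C1CCCCCC1`: 1.2 nM
- compound 2 `O=C1Nc2ccccc2C1(c1ccc(O)cc1)c1ccc(F)cc1`: 28 nM
- compound 3 `O=C1Nc2ccccc2C1(c1ccc(O)cc1)C1CCCCCC1`: 247 nM

Compound 3 has the highest of the three numbers. Compound 4 `O=C1Nc2c(C(F)(F)F)cccc2C1(c1ccc(O)cc1)C1CCCCCC1` has trifluoromethyl in place of hydrogen on an aromatic carbon of the core: trifluoromethyl in place of hydrogen on an aromatic carbon. For the measured compounds named here, the only measured step, an 8.8-fold higher number from compound 2 to compound 3 (0.95 log units; beyond the scatter), changes a different place and so bears only indirectly on this change. Compound 1 also carries cycloheptyl, has a substituted core and gives 1.2 nM, well below compound 3 at 247 nM. Going by the values given here, no measured step isolates trifluoromethyl, so a moderate move to a lower number is expected, with wide uncertainty. The estimated change in this assay is a 4.9-fold lower number from compound 3 to compound 4 (0.69 log units; beyond the scatter). The expected value for compound 4 is 50 nM, with an estimated range of 8 nM to 250 nM.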

Compound 4, half-maximal inhibitory concentration: 9.7 nM
Estimate against measurement, compound 4: 5.2-fold (0.71 log units) above; the range from low to high includes it.
By their numbers in this assay, from the lowest: compound 1; then compound 4; then compound 2; then compound 3.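

In this assay, trifluoromethyl in place of hydrogen on an aromatic carbon of the core gives a 25-fold lower number from compound 3 to compound 4 (1.41 log units; beyond the scatter). For the compounds shown here, this is the first step that isolates a substituent on the core, since the earlier step changed only the group on the saturated ring carbon. Nothing available accounts for the size of this step.

Going by these compounds, whether methyl, chlorine or methoxy on the same aromatic carbon gives a comparable step remains open. So does whether trifluoromethyl has a similar effect with 4-fluorophenyl in place of cycloheptyl.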